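The source may hold more compounds than are shown below. What is called first, only, known or untested is meant among the compounds shown, and "the series" means these compounds.

Measured compounds:
- compound 1, `CN1CCN(Cc2ccc(NC(=O)Nc3ccc4ncnc(Nc5ccc(F)c(F)c5)c4c3)cc2)CC1`: > 10000 nM
- compound 2, `O=C(Nc1ccc(CN2CCCC2)cc1)Nc1ccc2ncnc(Nc3cccc(C(F)(F)F)c3)c2c1`: 830 nM
- compound 3, `O=C(Nc1cccc(CN2CCCCC2)c1)Nc1ccc2ncnc(Nc3cccc(C(F)(F)F)c3)c2c1`: 1060 nM

Three compounds sharing one core were tested in a functional assay on A549 cells (Homo sapiens) for antiproliferative activity, read by MTT assay, with a stated time of 72 h; on this read-out higher numbers stand for weaker inhibition and lower numbers for stronger inhibition. Compound 1 `CN1CCN(Cc2ccc(NC(=O)Nc3ccc4ncnc(Nc5ccc(F)c(F)c5)c4c3)cc2)CC1` gives only a limit, > 10000 nM, which is the limit of > 10000 nM in this assay, at which 1 of the 3 values shown sits. Among the two compounds that return a number, compound 2 `O=C(Nc1ccc(CN2CCCC2)cc1)Nc1ccc2ncnc(Nc3cccc(C(F)(F)F)c3)c2c1` has the lowest with 830 nM. Its nearest neighbour is compound 3 `O=C(Nc1cccc(CN2CCCCC2)c1)Nc1ccc2ncnc(Nc3cccc(C(F)(F)F)c3)c2c1` at 1060 nM, and the gap between the two lies within the usual scatter, so they are best read as alike in this assay.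

The step to be followed goes from compound 2 to compound 4 `COc1ccc(NC(=O)Nc2ccc3ncnc(Nc4cccc(C(F)(F)F)c4)c3c2)cc1`. The change is methoxy in place of (pyrrolidin-1-yl)methyl on an aromatic carbon, para to a large group. Going by the values given here, no measured pair in this set shows that exact exchange, so its size is uncertain. The expectation is a moderate weakening, a step of a 2.4-fold higher number from compound 2 to compound 4 (0.38 log units; beyond the scatter) in this assay. Compound 4 is therefore estimated at 2000 nM, with a likely range from 500 nM to 8000 nM.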

Compound 4, half-maximal inhibitory concentration: 9470 nM
Compound 4: the middle estimate sits 4.7-fold (0.68 log units) below what was measured, and the stated range ends below it.
By their numbers in this assay, from the lowest: compounds 2 and 3 (each within the scatter of the next); then compound 4. At a limit, above all of these: compound 1.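

Replacing (pyrrolidin-1-yl)methyl with methoxy on this aromatic carbon, para to a large group, gives an 11-fold higher number from compound 2 to compound 4 (1.06 log units; beyond the scatter) in this assay, so what this position carries clearly matters in this series. The earlier compounds shown here all carried a saturated nitrogen ring on a methylene, so none of them showed what happens when that unit is gone, and this step shows a large loss even though the count of hydrogen-bond acceptors stays the same on both sides. Compound 4 now stands close to where the read-out stops, and the only compound closer is compound 1, which gives a limit and not a number: the limit of > 10000 nM in this assay, at which 1 of the 4 values shown sits.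

This single exchange removes the nitrogen, the ring and several heavy atoms together, and the compounds shown do not tell which of these accounts for the step. An open-chain dimethylaminomethyl group at the same place would keep the amine without the ring, and a plain methyl would keep the methylene carbon without the amine, so either could begin to separate the two.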